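Moving the thiophene attachment point on compound 2

The compounds below may be only part of what the source reports. "The series", "measured", "known", "first", "only" and "open" are said of these compounds alone.

Compound 2 `c1cn2cc(-c3ccsc3)nc(-c3ccc4ncn(C5CCCCC5)c4c3)c2n1` gives the highest of the three numbers in a functional assay on SK-MEL-5 cells (Homo sapiens) for inhibition, read by sulforhodamine B assay, with a stated time of 48 h, tested at 10 uM (a higher number here means more inhibition at the concentration tested (going by the name of the read-out), a lower number less inhibition), with 25%. Compound 1 `Brc1cn2ccnc2c(-c2ccc3ncn(C4CCCCC4)c3c2)n1` gives 13.4% and compound 3 `Clc1ccc(-c2cn3ccnc3c(-c3ccc4ncn(C5CCCCC5)c4c3)n2)cc1` gives 12.4%. The steps of a number 11.6 percentage points higher from compound 1 to compound 2 (beyond the scatter) and a number 12.6 percentage points lower from compound 2 to compound 3 (beyond the scatter) set compound 2 apart from both, while a number 1 percentage points lower from compound 1 to compound 3 (within the scatter) leaves compound 1 and compound 3 alike. Compound 4 `c1csc(-c2cn3ccnc3c(-c3ccc4ncn(C5CCCCC5)c4c3)n2)c1` differs from compound 2 by thiophen-2-yl in place of thiophen-3-yl on an aromatic carbon. Going by the values given here, none of the measured steps exchanges one thiophenyl for another; each replaces a bromo or compares a thiophenyl with a 4-chlorophenyl, so they speak to this switch only loosely. The expected step of a number 3 percentage points lower from compound 2 to compound 4 (within the scatter) is therefore small, within the scatter, with no direction favoured. Compound 4 is estimated at 22%, between 10% and 35%.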

Compound 4, a percentage reported as inhibition, at one concentration (the size of the read-out at that concentration, not a potency): 8.05%
Compound 4: the middle estimate sits 14 percentage points above what was measured, outside the stated range (below it).
By their numbers in this assay, from the lowest: compounds 4, 3 and 1 (each within the scatter of the next); then compound 2.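

In this assay the attachment point of the thiophene counts at this position: the two compounds hold the same atoms, yet a number 17 percentage points lower from compound 2 to compound 4 (beyond the scatter) lies beyond the scatter, so the higher number of compound 2 belongs to thiophen-3-yl and not to thiophene as such. By contrast, a number 4.4 percentage points lower from compound 3 to compound 4 (within the scatter) and a number 5.4 percentage points lower from compound 1 to compound 4 (within the scatter) both lie within the scatter, leaving compound 2 alone above the other three. No measurement here explains the gap between the two thiophenyl groups. As far as these compounds go, whether thiophen-3-yl stands out among five-membered aromatic rings stays open, as a furan or a pyrazole would show. So does the outcome of an amine at this position.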